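This account rests on a few compounds, and the source may have more. Where it says the series, first, only, none or still open, it means among the compounds named here.

Going by the values given here, in a functional assay on K562 cells (Homo sapiens) for cytotoxicity, read by trypan blue exclusion, with a stated time of 96 h (a lower number here means a stronger inhibitor, a higher number a weaker inhibitor), compound 3 (`COc1cc(OC)c(/C=C/S(=O)(=O)Nc2ccc(OC)c(F)c2)c(OC)c1`) gives 75 nM, the lowest of the three numbers so far. Compound 1 (`COc1cc(OC)c(/C=C/S(=O)(=O)Nc2ccc(F)c(N)c2)c(OC)c1`) gives 5000 nM, and compound 2 (`COc1ccc(NS(=O)(=O)/C=C/c2cc(OC)c(OC)c(OC)c2)cc1`) gives 35000 nM. Compound 4 (`COc1cc(OC)c(/C=C/S(=O)(=O)Nc2ccc(OC)c([N+](=O)[O-])c2)c(OC)c1`) differs from compound 3 in one place: nitro in place of fluoro on an aromatic carbon, ortho to a methoxy group (nitro in place of fluoro on an aromatic carbon). Among the compounds with values here, the one measured step that bears on this is a 67-fold lower number from compound 1 to compound 3 (1.82 log units; beyond the scatter), a large change in this assay that involves the same aromatic group. Within the data shown here, that step does not swap fluoro for nitro, and no measured step does, so its direction cannot simply be carried over. A modest rise, with wide uncertainty, is expected: a 2.0-fold higher number from compound 3 to compound 4 (0.30 log units; within the scatter). For compound 4 the estimated value is 150 nM, with a range of 30 nM to 1500 nM.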

Compound 4, half-maximal inhibitory concentration: 1000 nM
For compound 4 the middle estimate is 6.7-fold (0.82 log units) below the measured one; low and high end bracket the measured number.
By their numbers in this assay, from the lowest: compound 3; then compound 4; then compound 1; then compound 2.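

In this assay, this place on the ring, ortho to a methoxy group, does not accept every group alike: nitro in place of fluoro costs much of the activity (a 13-fold higher number from compound 3 to compound 4 (1.12 log units; beyond the scatter)). The earlier step replaced two groups on the aromatic ring, whereas this one changes a single group, so the effect of this one place is seen alone. Nothing measured here explains the size of this step.

On these data alone, it remains open whether a chloro group, a nitrile or an amine at this place would give a number close to that of compound 3 or of compound 4.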